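Phenyl Enters Compound 2 on the Ring Carbon

The compounds below may be only part of what the source reports. "The series", "measured", "known", "first", "only" and "open" are said of these compounds alone.

Of the compounds shown here, two have been measured in a functional assay on PC-12 cells (Rattus norvegicus) for cytotoxicity, read by MTT assay, with stated times of 3 h and 2 h, tested at 20 uM; on this read-out higher numbers stand for a stronger effect at the one concentration tested and lower numbers for a weaker effect. Compound 1 `O=C(CCCCC1CCSS1)NCc1cn(CCCOc2ccc3cc(-c4ccccc4)c(=O)oc3c2)nn1` gives 27.2% in this assay. Compound 2 `O=C(CCCCC1CCSS1)NCc1cn(CCCCOc2ccc3ccc(=O)oc3c2)nn1` reaches 69.8%, the higher of the two numbers, with compound 1 lying below it by a gap beyond the scatter. For the measured compounds named here, the two differ in more than one place, so no single step between them can be drawn; their values can only be set side by side. Compound 3 `O=C(CCCCC1CCSS1)NCc1cn(CCCCOc2ccc3cc(-c4ccccc4)c(=O)oc3c2)nn1` is compound 2 with one change: phenyl in place of hydrogen on an aromatic carbon. Compound 1, which also carries a phenyl there, gives only 27.2% in this assay, and that is the sole hint available. On that basis a downward step in this assay is expected, of a size beyond the scatter, as a number 29.8 percentage points lower from compound 2 to compound 3 (beyond the scatter) expresses. Compound 3 is accordingly estimated at 40%, within a range from 20% to 62%.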

Compound 3, a percentage reported as activity, at one concentration (the size of the read-out at that concentration, not a potency): 26%
Beside the measured number, compound 3's estimate is 14 percentage points above it, within the range that was stated.
By their numbers in this assay, from the lowest: compounds 3 and 1 (each within the scatter of the next); then compound 2.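

In this assay, for the compounds shown here, phenyl in place of hydrogen on this aromatic carbon gives a number 43.8 percentage points lower from compound 2 to compound 3 (beyond the scatter) and so provides the first direct reading of this change, which the earlier pair, differing in more than one place, could not give. With the same phenyl at this position, compound 1 at 27.2% and compound 3 at 26% lie within the scatter of each other. Nothing measured here bears on why the step has this size.

As far as these compounds go, whether the step belongs to phenyl specifically or would also appear with another group remains open, and a methyl, an amine or a carboxylic acid on this same carbon would address that. The single concentration also leaves open how the step would look at other concentrations.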